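The compounds below may be only part of what the source reports. "The series", "measured", "known", "first", "only" and "open" are said of these compounds alone.

Of the compounds shown here, three have been measured so far in a functional assay on CHO-K1 cells for antagonist activity at adenosine receptor A1 (Homo sapiens), read by a beta-galactosidase reporter and cAMP accumulation, with stated times of 15 min and 6 h; on this read-out lower numbers stand for stronger inhibition and higher numbers for weaker inhibition. Compound 1 `Cc1ccc(-c2nc(N)c3cc(CCc4ccccc4)sc3n2)o1` gives 2780 nM, compound 2 `CC(C)c1ccc(-c2nc(N)c3cc(Cc4ccccc4)sc3n2)o1` gives 283 nM, and compound 3 `CC(c1ccccc1)c1cc2c(N)nc(-c3cccc(C#N)c3)nc2s1` gives 1770 nM. Compound 2 thus stands lowest of the three numbers and is the most potent of the set; its nearest neighbour is compound 3 and its furthest is compound 1, and both gaps lie beyond the usual scatter of repeated measurements.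

The next compound, compound 4 `Nc1nc(-c2cccc(F)c2)nc2sc(Cc3ccccc3)cc12`, has not yet been measured. It differs from compound 2 in one place: 3-fluorophenyl in place of 5-isopropylfuran-2-yl on an aromatic carbon. The 5-isopropylfuran-2-yl group leaves and a 3-fluorophenyl group enters, on an aromatic carbon of a six-membered aromatic ring with 2 nitrogen, part of a fused system of two rings.

Within the data shown here, no two measured compounds differ only in this place, so no measured step guides the expectation directly. Compound 3, whose group on the shared core is also a six-membered aromatic ring of carbon only rather than a furan, gives 1770 nM, a weaker number, but it differs from compound 2 elsewhere too. The expected step is a moderate loss beyond the scatter, a 2.8-fold higher number from compound 2 to compound 4 (0.45 log units; beyond the scatter). Compound 4 is therefore estimated at about 800 nM, within a range from 250 nM to 2500 nM.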

Compound 4, inhibition constant: 123 nM
Beside the measured number, compound 4's estimate is 6.5-fold (0.81 log units) above it, outside the stated range (below it).
By their numbers in this assay, from the lowest: compound 4; then compound 2; then compounds 3 and 1 (each within the scatter of the next).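

In this assay, among these compounds, replacing 5-isopropylfuran-2-yl with 3-fluorophenyl gives a 2.3-fold lower number from compound 2 to compound 4 (0.36 log units; beyond the scatter) and provides the first direct reading at this position, an aromatic carbon between two ring nitrogen atoms on the shared core. The change is modest but beyond the scatter, and it shows that, on this core with its benzyl group unchanged, the furan ring and its oxygen are not required for the stronger number: a six-membered aromatic ring of carbon only, with no hydrogen-bond acceptor counted in the group, gives a lower number than the furan group. No measurement available here accounts for this difference.

This single step changes the ring and its substituent together, so it cannot show how much of the shift belongs to the ring and how much to the fluorine, a question that plain phenyl, furan-2-yl without the isopropyl group, or 5-methylfuran-2-yl on this same core would address. On these data alone, how far the position tolerates other groups also stays open, for instance a pyridine ring, a simple amine, 3-chlorophenyl or 3-methoxyphenyl.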